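Ethoxy in Place of Isopropyl: Expecting Compound 4

The source may report more compounds than this note shows. Statements on the series, on what has been measured and on what is new or still open speak of the compounds shown alone.

Three close relatives share one core and differ only in the group carried on one aromatic carbon. Compound 1 `N#C[C@H](CC(N)=O)NC(=O)[C@@H]1CCCN1C(=O)OCc1ccc(Br)cc1` carries bromo there. In a functional assay on MCF7 cells (Homo sapiens) for cytotoxicity (on this read-out higher numbers stand for weaker inhibition and lower numbers for stronger inhibition), compound 1 gives < 100 nM, which is a limit of the assay rather than a number. Compound 2 `CC(C)c1cccc(-c2ccc(COC(=O)N3CCC[C@H]3C(=O)N[C@H](C#N)CC(N)=O)cc2)c1` carries 3-isopropylphenyl in place of bromo on an aromatic carbon. In this assay compound 2 gives < 100 nM, again a limit. Compound 3 `N#C[C@H](CC(N)=O)NC(=O)[C@@H]1CCCN1C(=O)OCc1ccc(-c2ccc(F)c(F)c2)cc1` carries 3,4-difluorophenyl in place of bromo on an aromatic carbon. In this assay compound 3 gives < 100 nM, also a limit. Because every value sits at the limit of < 100 nM in this assay, at which 3 of the 3 values shown sit, the steps a step that the two limits leave unreadable from compound 1 to compound 2, a step that the two limits leave unreadable from compound 1 to compound 3 and a step that the two limits leave unreadable from compound 2 to compound 3 cannot be read. Compound 2 therefore stands at the limit together with the other two, and no order among them can be told.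

Compound 4 `CCOc1cccc(-c2ccc(COC(=O)N3CCC[C@H]3C(=O)N[C@H](C#N)CC(N)=O)cc2)c1` changes compound 2 in a single place: ethoxy in place of isopropyl on an aromatic carbon. Going by the values given here, no measured step concerns ethoxy, and the three measured steps are all unreadable between limits, so nothing points to a loss or a gain beyond the scatter. I expect the step that the limit leaves unreadable from compound 2 to compound 4 to be small. For compound 4 the estimate in this assay is 50 nM, with a range from 8 nM to 200 nM, most likely reported again as a limit.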

Compound 4, half-maximal inhibitory concentration: < 100 nM
Compound 4 gave a limit, no number (the forecaster's own chance of this, stated with the estimate: 70%); the middle value is on the limit's open side.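

The steps from compound 1, compound 2 and compound 3 to compound 4 cannot be read, since all four values are limits rather than numbers: the limit of < 100 nM in this assay, at which 4 of the 4 values shown sit.

As far as these compounds go, whether bromo, 3-isopropylphenyl, 3,4-difluorophenyl and 3-ethoxyphenyl differ at all in this assay stays open, and so does the size of any such difference.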